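This account rests on a few compounds, and the source may have more. Where it says the series, first, only, none or still open, it means among the compounds named here.

Measured so far:
compound 1 `Cc1ccccc1NC(=O)CSc1nncnc1-c1cccc2ccccc12` — 158000 nM
compound 2 `Cc1ccccc1NC(=O)CSc1nncnc1-c1ccccc1Cl` — 142000 nM
compound 3 `COC(=O)c1ccc(NC(=O)CSc2nncnc2-c2cccc3ccccc23)c(Br)c1` — 173000 nM

Of the compounds shown here, three sharing one core have been tested in an ADME assay on MT4 cells (Homo sapiens) for cytotoxicity, read by MTT assay; a lower number here means that less compound is tolerated, a higher number that more compound is tolerated. Compound 1 gives 158000 nM, the second highest of the three numbers; compound 3 at 173000 nM sits nearest to it, and compound 2 at 142000 nM furthest, yet both gaps fall within the scatter of this assay, so the three tolerate roughly the same amount of compound and no order among them can be read.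

Compound 4 `O=C(CSc1nncnc1-c1cccc2ccccc12)Nc1ccc(Cl)cc1Cl` has not yet been measured. It differs from compound 1 in one place: 2,4-dichlorophenyl in place of 2-methylphenyl on an amide-type nitrogen. Among the measured compounds shown here, no measured pair shows what this kind of change does in this assay, so there is nothing on file to scale it from; the three known values are simply close to one another.

Compound 4 is therefore expected to stay near compound 1, with at most a modest move toward a lower number, estimated as a 1.3-fold lower number from compound 1 to compound 4 (0.12 log units; within the scatter). The value of compound 4 in this assay is estimated at 120000 nM, within a range from 55000 nM to 250000 nM.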

Compound 4, half-maximal cytotoxic concentration: 254000 nM
For compound 4 the middle estimate is 2.1-fold (0.33 log units) below the measured one, and the stated range ends below it.
By their numbers in this assay, from the lowest: compounds 2, 1, 3 and 4 (each within the scatter of the next).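

The amide-type nitrogen now has its first one-place comparison: in this assay, 2,4-dichlorophenyl in place of 2-methylphenyl gives a 1.6-fold higher number from compound 1 to compound 4 (0.21 log units; within the scatter). On this single pair, the exchange of the methyl group for two chlorine atoms on the phenyl ring leaves compound 4 indistinguishable from compound 1, so this position accepts both aryl groups without a readable change in the amount of compound tolerated. No supporting data bear on why the two compounds read alike.

As far as these compounds go, it remains open whether a carboxylic acid or an amine on this phenyl ring, or a plain alkyl chain in its place, would produce a step beyond the scatter. The compounds shown also leave open whether this exchange would read the same with a different group on the shared core.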